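Isobutoxy in Place of Methoxy on Two Related Cores

This account rests on a few compounds, and the source may have more. Where it says the series, first, only, none or still open, it means among the compounds named here.

The measured compounds:
compound 1, `COc1ccc(-c2nc3cc(/C=C4\SC(=O)NC4=O)ccc3[nH]2)cc1OC`, with 8720 nM
compound 2, `COc1cc(-c2nc3cc(/C=C4\SC(=O)NC4=O)ccc3[nH]2)ccc1OCC(C)C`, with 2980 nM
compound 3, `COc1ccc(-c2nc3cc(/C=C4\SC(=O)N(Cc5cc(OC)c(OC)c(OC)c5)C4=O)ccc3[nH]2)cc1OC`, for which only a limit is known

In a functional assay on PC-3 cells (Homo sapiens) for inhibition, read by MTT assay, with a stated time of 48 h (a lower number here means a stronger inhibitor, a higher number a weaker inhibitor), compound 1 gives 8720 nM and compound 2 gives 2980 nM. The step of a 2.9-fold lower number from compound 1 to compound 2 (0.47 log units; beyond the scatter) belongs to the change (isopropyl in place of hydrogen on a saturated chain carbon bound to an oxygen on an aromatic ring). Compound 3 returns only a limit in this assay, > 50000 nM, which is the limit of > 50000 nM in this assay, at which 1 of the 3 values shown sits. How the core of compound 3 differs from the core of compound 1 is not broken down here.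

Compound 4, `COc1cc(-c2nc3cc(/C=C4\SC(=O)N(Cc5cc(OC)c(OC)c(OC)c5)C4=O)ccc3[nH]2)ccc1OCC(C)C`, has not been measured. It differs from compound 3 by isopropyl in place of hydrogen on a saturated chain carbon bound to an oxygen on an aromatic ring, the same change as that from compound 1 to compound 2, made at the same place. On the earlier step the isopropyl brought a modest gain, yet compound 3 sits at a limit, so a step of that size would still leave compound 4 near or beyond the limit. Compound 4 is therefore expected to show an at least 1.2-fold lower number from compound 3 to compound 4 (0.09 log units; that floor lies within the scatter), and its value is estimated at 40000 nM, between 12000 nM and 150000 nM.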

Compound 4, half-maximal inhibitory concentration: 110 nM
Compound 4: the middle estimate sits 360-fold (2.56 log units) above what was measured; measured number outside the range, below it.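

In this assay, the same change of methoxy to isobutoxy gives an at least 450-fold lower number from compound 3 to compound 4 (2.65 log units; beyond the scatter), so the lower number carries over from one core to the other but its size does not: the same change on two cores in this assay, a 2.9-fold lower number (0.47 log units; beyond the scatter) from compound 1 to compound 2 and an at least 450-fold lower number (2.65 log units; beyond the scatter) from compound 3 to compound 4, at least 150-fold (2.19 log units) apart, beyond the scatter of two such steps

On these data alone, compound 3 gives only a limit, > 50000 nM, so the true size of the second step remains unknown. These two pairs show a lower number on both cores, but they set no rule for other cores and do not explain why the size of the step differs.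

As far as these compounds go, it remains open whether the large step on the core of compound 3 is particular to isobutoxy, or whether a longer chain or a chain ending in an amine would give a similar result. From the compounds shown here alone, it is also open whether the change would behave the same way on a core carrying a plain benzyl group where compound 3 differs from compound 1.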